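Cyano in Place of Fluoro: An Expected Cytotoxicity Step

The source may report more compounds than this note shows. Statements on the series, on what has been measured and on what is new or still open speak of the compounds shown alone.

Compound 3 `O=c1ccoc2cc(OCc3cn(Cc4ccc(F)cc4)nn3)ccc12` was tested in a functional assay on SGC-7901 cells (Homo sapiens) for cytotoxicity, read by MTT assay, with a stated time of 48 h; on this read-out higher numbers stand for weaker inhibition and lower numbers for stronger inhibition. In this assay compound 3 gives > 100000 nM, which is a limit of the assay rather than a number. Compound 1 `O=c1ccoc2cc(OCc3cn(Cc4ccccc4)nn3)ccc12` gives > 100000 nM, also a limit. Compound 2 `Cc1ccccc1Cn1cc(COc2ccc3c(=O)ccoc3c2)nn1` gives > 100000 nM, again a limit. In short, (the limit of > 100000 nM in this assay, at which 3 of the 3 values shown sit). The steps a step that the two limits leave unreadable from compound 1 to compound 2, a step that the two limits leave unreadable from compound 1 to compound 3 and a step that the two limits leave unreadable from compound 2 to compound 3 accordingly have no readable size. Compound 4 `N#Cc1ccc(Cn2cc(COc3ccc4c(=O)ccoc4c3)nn2)cc1` has not been measured; it differs from compound 3 by cyano in place of fluoro on an aromatic carbon. Going by the values given here, all three measured values are limits, and none of the measured steps offers a readable size that bears on this change. The expected step is a step that the limit leaves unreadable from compound 3 to compound 4, leaving compound 4 at the same limit. The estimate for compound 4 is 150000 nM, ranging from 30000 nM to 600000 nM.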

Compound 4, half-maximal inhibitory concentration: > 100000 nM
Compound 4 was reported as a limit (the forecaster's own chance of this, stated with the estimate: 85%); the middle value lies beyond the limit too.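

Going by these compounds alone, no step to compound 4 from compound 1, compound 2 or compound 3 can be read, since all four compounds stand at one limit in this assay: the limit of > 100000 nM in this assay, at which 4 of the 4 values shown sit. The compounds shown leave open whether hydrogen, methyl, fluoro and cyano differ at all in cytotoxicity.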